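Amino Group Shortens Stability Half-Life in a Benzimidazole Pair

The compounds below may be only part of what the source reports. "The series", "measured", "known", "first", "only" and "open" are said of these compounds alone.

Four carbamoyl-imidazole compounds are compared in a physicochemical assay for metabolic stability, read by HPLC, at pH 4.5, tested at 10 uM; a lower number here means that the compound disappears faster, a higher number that the compound lasts longer. Compound 1 `Cc1ccccc1CNC(=O)n1cnc2ccccc21` gives 1.37 h. Compound 3 `Cc1ccccc1CNC(=O)n1c(N)nc2ccccc21` differs from compound 1 by one change, (amino in place of hydrogen on an aromatic carbon), and in this assay compound 3 gives 0.45 h. That change produced a 3.0-fold lower number from compound 1 to compound 3 (0.48 log units; beyond the scatter), so the added amino group went along with a clearly shorter half-life.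

Compound 2 `O=C(NCCCCc1ccccc1)n1cnc2ccccc21` carries a four-carbon chain to a phenyl ring in place of the methylbenzyl group of compound 1; how the two cores differ is not broken down here. In this assay compound 2 reached only the limit of > 2 h, and no exact number is known for it. For the measured compounds named here, compound 4 `Nc1nc2ccccc2n1C(=O)NCCCCc1ccccc1` is not yet measured; it differs from compound 2 by amino in place of hydrogen on an aromatic carbon, the same change as the one from compound 1 to compound 3, at the same place.

Because the earlier step was a 3.0-fold lower number from compound 1 to compound 3 (0.48 log units; beyond the scatter), a drop of similar size is expected here, giving an estimated step of an at least 2.0-fold lower number from compound 2 to compound 4 (0.30 log units; that floor lies within the scatter). Compound 4 is therefore expected to give about 1 h, most likely between 0.4 h and 3 h.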

Compound 4, half-life: 0.717 h
Beside the measured number, compound 4's estimate is 1.4-fold (0.14 log units) above it, within the range that was stated.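

Putting amino in place of hydrogen on an aromatic carbon went with a shorter half-life on both cores in this assay: the new pair shows an at least 2.7-fold lower number from compound 2 to compound 4 (0.44 log units; beyond the scatter), in the same direction as the earlier pair, which shows a 3.0-fold lower number from compound 1 to compound 3 (0.48 log units; beyond the scatter). Compound 2 has only a limit in this assay, not an exact number: the limit of > 2 h in this assay, at which 1 of the 4 values shown sits. The new step is therefore a minimum, so the pairs do not show whether the change has the same size on both cores, and two pairs make no general rule for other cores in this series.

The compounds shown leave open whether a methyl group, a hydroxyl group or a dimethylamino group at the same place would also go with a shorter half-life. They also leave open whether the amino step would hold with a longer chain or with a carboxylic acid on the phenyl ring.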